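The source may hold more compounds than are shown below. What is called first, only, known or untested is meant among the compounds shown, and "the series" means these compounds.

Compound 3 `Cn1c(=O)c2c(nc(SCc3ccc(Cl)cc3)n2C)n(C)c1=O` gives the lowest number of the three compounds in an assay on isolated protein for inhibition of Amine oxidase [flavin-containing] A (Homo sapiens), read by fluorescence (on this read-out lower numbers stand for stronger inhibition and higher numbers for weaker inhibition), at 2770 nM. Compound 1 `Cn1c(=O)c2c(nc(SCc3ccccc3)n2C)n(C)c1=O` gives 8220 nM, and compound 2 `Cn1c(=O)c2c(nc(SCCOc3ccccc3)n2C)n(C)c1=O` gives 15500 nM. The step of a 3.0-fold lower number from compound 1 to compound 3 (0.47 log units; beyond the scatter) and the step of a 5.6-fold lower number from compound 2 to compound 3 (0.75 log units; beyond the scatter) both point to the 4-chlorophenyl group as what sets compound 3 apart, while the step of a 1.9-fold higher number from compound 1 to compound 2 (0.28 log units; within the scatter) stays small. Compound 4 `CC(C)CCSc1nc2c(c(=O)n(C)c(=O)n2C)n1C` removes that group: isobutyl in place of 4-chlorophenyl on a saturated chain carbon bound to a sulfur. Among the measured compounds shown here, no measured step swaps an aromatic ring for a plain chain, so the only guide is the loss of what the chloro and the ring contributed in the steps to compound 3. Compound 4 is therefore expected to give a higher number, a step of a 4.3-fold higher number from compound 3 to compound 4 (0.64 log units; beyond the scatter), with an estimate of 12000 nM, between 4000 nM and 35000 nM.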

Compound 4, half-maximal inhibitory concentration: 15200 nM
Compound 4: the middle estimate sits 1.3-fold (0.10 log units) below what was measured, and the stated range covers the measured number.
By their numbers in this assay, from the lowest: compound 3; then compounds 1, 4 and 2 (each within the scatter of the next).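

On a saturated chain carbon bound to a sulfur, isobutyl in place of 4-chlorophenyl gives a 5.5-fold higher number from compound 3 to compound 4 (0.74 log units; beyond the scatter) while isobutyl in place of phenyl gives only a 1.8-fold higher number from compound 1 to compound 4 (0.27 log units; within the scatter) and isopropyl in place of phenoxy gives a 1.0-fold lower number from compound 2 to compound 4 (0.01 log units; within the scatter). A ringless chain therefore cannot be told apart from the plain phenyl or the phenoxy end, and among these four compounds only the 4-chlorophenyl group stands out. Nothing available explains this result. Open, from the compounds shown here alone, is whether bromo or methoxy in place of the chloro would match it, and whether a longer chain or an amine at the chain end would shift the number.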